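Series notes: carbonyl aryl group, compound 2 to compound 3

The compounds below may be only part of what the source reports. "The series", "measured", "known", "first", "only" and "open" are said of these compounds alone.

Measured in a functional assay on A549 cells (Homo sapiens) for antiproliferative activity, read by XTT assay, with a stated time of 72 h; a higher number here means a weaker inhibitor, a lower number a stronger inhibitor:
compound 1 `COc1ccc(-c2cc3ccccc3nc2/C=C/C(=O)c2ccc(Br)s2)cc1` gives 6250 nM
compound 2 `COc1ccc(-c2cc3ccccc3nc2/C=C/C(=O)c2ccc[nH]2)cc1` gives > 10000 nM, a limit of the assay

Compound 2 stands only at a limit of this assay; its number is not known, it is one of the values at the limit of > 10000 nM in this assay, at which 1 of the 2 values shown sits. Among the compounds with values here, the only measured step is an at least 1.6-fold higher number from compound 1 to compound 2 (0.20 log units; that floor lies within the scatter), which carries a 1H-pyrrol-2-yl in for a 5-bromothiophen-2-yl on the carbonyl carbon.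

Compound 3 `COc1ccc(-c2cc3ccccc3nc2/C=C/C(=O)c2sccc2N)cc1` is not yet measured. It differs from compound 2 by 3-aminothiophen-2-yl in place of 1H-pyrrol-2-yl on a carbonyl carbon. A thiophene ring thus returns on the carbonyl carbon, as in compound 1, but with an amino group in place of the bromo. Within the data shown here, the one measured step points the other way and its floor lies within the scatter, so the basis is thin. Compound 3 is expected to move back toward compound 1, giving a step of an at least 1.2-fold lower number from compound 2 to compound 3 (0.09 log units; that floor lies within the scatter), though a further limit cannot be excluded. Compound 3 is estimated at 8000 nM, with a range from 3000 nM to 20000 nM in this assay.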

Compound 3, half-maximal inhibitory concentration: > 10000 nM
Compound 3 was reported as a limit (the forecaster's own chance of this, stated with the estimate: 40%); middle value at least 1.2-fold (0.09 log units) away from the limit.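

In this assay, a thiophene ring on the carbonyl carbon is not enough on its own to give a value inside the range of the assay: 3-aminothiophen-2-yl in place of 5-bromothiophen-2-yl gives an at least 1.6-fold higher number from compound 1 to compound 3 (0.20 log units; that floor lies within the scatter). This step is only a floor and lies within the scatter, so it does not establish that the amino-bearing ring is weaker than the bromo-bearing one. The step between compound 2 and compound 3 cannot be read, and with this result both the 1H-pyrrol-2-yl and the 3-aminothiophen-2-yl group leave the series at the limit of the assay, so compound 1 remains the only one of the three with a number: the limit of > 10000 nM in this assay, at which 2 of the 3 values shown sit.

On these data alone, how far compound 2 and compound 3 lie past that limit stays open, and no order can be set between their two groups. Also open, as far as these compounds go, is whether the bromo group or the thiophene ring matters more for the value of compound 1, a question that a plain thiophen-2-yl or a 5-chlorothiophen-2-yl on the same carbonyl carbon would bear on directly.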